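The source may report more compounds than this note shows. Statements on the series, on what has been measured and on what is new or still open speak of the compounds shown alone.

Notes on the series. Compound 2 `COc1ncnc2c1c(-c1ccsc1)cn2[C@@H]1O[C@H](CO)[C@@H](O)[C@H]1O` gives 140 nM in a functional assay on HCT-116 cells (Homo sapiens), read by MTT assay, with a stated time of 72 h (a higher number here means a weaker inhibitor, a lower number a stronger inhibitor), and stands lowest of the two numbers in hand. Compound 3 `O=c1[nH]cnc2c1c(-c1ccoc1)cn2[C@@H]1O[C@H](CO)[C@@H](O)[C@H]1O` gives 14800 nM in this assay, the nearest value, a gap from compound 2 that lies beyond the scatter. Compound 1 `Nc1nc(N)c2c(-c3ccsc3)cn([C@@H]3O[C@H](CO)[C@@H](O)[C@H]3O)c2n1` sits at a limit of the assay, > 20000 nM in this assay, so no number is known for it (the limit of > 20000 nM in this assay, at which 1 of the 3 values shown sits). Compound 4 `CN(C)c1ncnc2c1c(-c1ccsc1)cn2[C@@H]1O[C@H](CO)[C@@H](O)[C@H]1O` is not yet measured; its change from compound 2 is dimethylamino in place of methoxy on an aromatic carbon. Within the data shown here, no step between measured compounds of this kind is available, so the size can only be judged loosely. Compound 4 is expected to give a somewhat higher number, an expected step of a 2.1-fold higher number from compound 2 to compound 4 (0.33 log units; beyond the scatter). The estimate for compound 4 in this assay is 300 nM, within 60 nM to 2000 nM.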

Compound 4, half-maximal inhibitory concentration: > 20000 nM
Compound 4: a limit, no number (the forecaster's own chance of this, stated with the estimate: 5%); middle value at least 66-fold (1.82 log units) away from the limit.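

In this assay, dimethylamino in place of methoxy on this aromatic carbon gives an at least 140-fold higher number from compound 2 to compound 4 (2.15 log units; beyond the scatter), the first step read at this position, and a large one. Compound 4 gives > 20000 nM, a limit of the assay and not a number: the limit of > 20000 nM in this assay, at which 2 of the 4 values shown sit. Methoxy and dimethylamino match in their counts of hydrogen-bond donors and acceptors, so those counts do not separate compound 2 from compound 4.

Going by these compounds, whether methylamino, ethoxy or a plain methyl on this carbon stays near compound 2 remains open. So does whether the methoxy result holds with other groups on the shared core.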